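Exchanging a Sulfonate Ester for a Biaryl: Cytotoxicity Outlook

The compounds below may be only part of what the source reports. "The series", "measured", "known", "first", "only" and "open" are said of these compounds alone.

Measured compounds:
compound 1 `C=C[C@@](C)(/C=C/c1ccc(OS(=O)(=O)C(F)(F)F)cc1)CCC=C(C)C` — > 36600 nM
compound 2 `C=C[C@@](C)(/C=C/c1ccc(OS(=O)(=O)c2ccc(C)cc2)cc1)CCC=C(C)C` — > 36600 nM
compound 3 `C=C[C@@](C)(/C=C/c1ccc(O)cc1)CCC(O)C(C)(C)O` — > 36600 nM

In an ADME assay on BJ cells (Homo sapiens) for cytotoxicity, with a stated time of 72 h (a higher number here means that more compound is needed for the effect, a lower number that less compound is needed), compound 1 gives > 36600 nM, which is a limit of the assay and not a number. Compound 2 gives > 36600 nM, likewise a limit. Compound 3 gives > 36600 nM, again a limit. Compound 1 therefore stands where every measured compound stands: at the limit of > 36600 nM in this assay, at which 3 of the 3 values shown sit, with no number of its own.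

Going by the values given here, the one single-point step among the measured compounds, a step that the two limits leave unreadable from compound 1 to compound 2, is a change on the sulfonyl sulfur that cannot be sized, since both ends are limits.

Compound 4 `C=C[C@@](C)(/C=C/c1ccc(-c2cccc(F)c2)cc1)CCC=C(C)C` differs from compound 1 as follows: 3-fluorophenyl in place of ((trifluoromethyl)sulfonyl)oxy on an aromatic carbon. Among the compounds with values here, no measured step replaces a sulfonyloxy group with an aromatic ring, so the only evidence bearing on this change is that all three measured compounds, including the unreadable step from compound 1 to compound 2, sit at the limit. On that basis the step from compound 1 to compound 4 is expected to be none beyond the scatter, with the assay most likely again reporting a limit: a step that the limit leaves unreadable from compound 1 to compound 4.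

Compound 4 is accordingly estimated at 40000 nM, in the range 15000 nM to 100000 nM.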

Compound 4, half-maximal effective concentration: > 36600 nM
Compound 4 ended at the assay's limit; the forecaster's own chance of this, stated with the estimate: 65%; the middle value is on the limit's open side.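

Going by these compounds alone, compound 4, like compound 1, returns only a limit of the assay and not a number, so no step between the two can be read, and the result joins the others: the limit of > 36600 nM in this assay, at which 4 of the 4 values shown sit. The compounds shown leave open what concentration any of them would need for the half-maximal effect in this assay and whether 3-fluorophenyl in place of ((trifluoromethyl)sulfonyl)oxy alters it.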